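Swapping a Thiazole for a Benzimidazole on a Shared Core

The compounds below may be only part of what the source reports. "The series", "measured", "known", "first", "only" and "open" are said of these compounds alone.

Of the compounds shown here, two have been tested in a functional assay for inhibition of Polyunsaturated fatty acid 5-lipoxygenase (Homo sapiens); on this read-out lower numbers stand for stronger inhibition and higher numbers for weaker inhibition. Compound 1, `C/C(=N\OC(CCCc1ccc(F)cc1)c1ccc(OCc2ccc3ccccc3n2)cc1)C(=O)O`, gives 9 nM in this assay. Compound 2, `C/C(=N\OC(c1ccc(OCc2cscn2)cc1)C1CCCCC1)C(=O)O`, gives 360 nM. Of the two numbers, that of compound 2 is the higher one, meaning the weaker inhibition, and the gap to compound 1 lies beyond the usual scatter. The two compounds differ in more than one place, so no single cause can be read from that gap.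

Compound 3, `C/C(=N\OC(c1ccc(OCc2nc3ccccc3n2C)cc1)C1CCCCC1)C(=O)O`, has not yet been measured. It differs from compound 2 in one place: 1-methyl-1H-benzimidazol-2-yl in place of 1,3-thiazol-4-yl on a saturated chain carbon bound to an oxygen on an aromatic ring. The entering group brings one six-membered aromatic ring of carbon only in addition to its five-membered aromatic ring, so it is the larger of the two groups.

Within the data shown here, with only two measured compounds and no matched step between them, the expectation rests mainly on the fact that compound 1, with a two-ring group at the same kind of position, gives 9 nM. On that basis compound 3 is expected to give a lower number, a step of about a 4.5-fold lower number from compound 2 to compound 3 (0.65 log units; beyond the scatter) in this assay, beyond the scatter. The estimate for compound 3 is 80 nM, within a range from 20 nM to 400 nM.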

Compound 3, half-maximal inhibitory concentration: 820 nM
Estimate against measurement, compound 3: 10-fold (1.01 log units) below; the whole stated range lies below it.
By their numbers in this assay, from the lowest: compound 1; then compound 2; then compound 3.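

Among these compounds, this is the first change made in one place only, so it is the first direct test of this position on the shared core. In this assay, putting 1-methyl-1H-benzimidazol-2-yl in place of 1,3-thiazol-4-yl gives a 2.3-fold higher number from compound 2 to compound 3 (0.36 log units; beyond the scatter), a modest step that still lies beyond the usual scatter, so on this core the larger group with its added six-membered aromatic ring goes with weaker inhibition, not stronger. No measurement offered here explains why the number moves in this direction.

The step swaps a whole group, so the added ring, the methyl and the loss of the sulfur all change together, and this pair cannot show which of them matters. A 1H-benzimidazol-2-yl group without the methyl would separate the methyl from the added ring, and a plain phenyl group in the same place would show whether a five-membered aromatic ring with hetero atoms is needed at all.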